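The source may report more compounds than this note shows. Statements on the series, on what has been measured and on what is new or still open speak of the compounds shown alone.

Measured compounds:

Compound 1 `COc1cccc2c1CCCC2NC(=O)C[C@@H]1C(=O)NC=CN1S(=O)(=O)c1ccc(C)cc1`; in an in vitro functional assay on cells for antagonist activity at B1 bradykinin receptor (Homo sapiens), read by luminescence and calcium flux, with a stated time of 2 h (on this read-out lower numbers stand for stronger inhibition and higher numbers for weaker inhibition), compound 1 gives 36.1 nM.
Compound 2 `Cc1ccc(S(=O)(=O)N2C=CNC(=O)[C@H]2CC(=O)NC2CCCCC2C)cc1`; in this assay compound 2 gives 25.9 nM.
Compound 3 `Cc1cc(S(=O)(=O)N2C=CNC(=O)[C@H]2CC(=O)N2CC[C@H](N3CCCC3)C2)c(C)cc1Cl`; in this assay compound 3 gives 19 nM.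

All three share the same core and differ only in the group on the amide carbonyl. Compound 3 carries the lowest of the three numbers, yet its gap to compound 2 and its gap to compound 1 both lie within the scatter, so no order among the three can be read from these values. For the measured compounds named here, no pair in this set differs in a single place, so no measured step is available on which to judge the size of a change at the amide.

Compound 4 `Cc1cc(S(=O)(=O)N2C=CNC(=O)[C@H]2CC(=O)N2C[C@H]3CN(C)C[C@H]3C2)c(C)cc1Cl` has not been measured. It differs from compound 3 in one place: a group of 9 heavy atoms (7 carbon, 2 nitrogen; 2 five-membered non-aromatic rings with 1 hetero atom each) in place of a group of 10 heavy atoms (8 carbon, 2 nitrogen; 2 five-membered non-aromatic rings with 1 hetero atom each), on a carbonyl carbon. The two groups are close in size and in count of nitrogen atoms, and both are built from two five-membered non-aromatic rings with one hetero atom each. Nothing in the measured set shows how an exchange of this kind moves the number. The step from compound 3 to compound 4 is therefore expected to be a 1.2-fold higher number from compound 3 to compound 4 (0.06 log units; within the scatter), with no direction favoured and no change beyond the scatter assumed. Compound 4 is estimated at 22 nM, within 8 nM to 60 nM.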

Compound 4, half-maximal inhibitory concentration: 136 nM
Compound 4: the middle estimate sits 6.2-fold (0.79 log units) below what was measured; the whole stated range lies below it.
By their numbers in this assay, from the lowest: compounds 3, 2 and 1 (each within the scatter of the next); then compound 4.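

In this assay, for the compounds shown here, the group on the carbonyl carbon turns out to be sensitive to the exact form of the amine: a 7.2-fold higher number from compound 3 to compound 4 (0.85 log units; beyond the scatter) is the only single-place step in the set, and it lies beyond the scatter. The exchange keeps the two five-membered non-aromatic rings with 1 hetero atom each, the hydrogen-bond donor and acceptor counts and the absence of net charge, so agreement in these counts does not by itself hold the number in place at this position; what does differ is the count of heavy atoms, with 2 defined stereocentres against 1. No measurement on hand accounts for the size of this step.

With one pair, the difference in heavy atoms, the stereocentres and the way the two rings are joined cannot be separated as sources of the step. Also open, on these data alone, is whether a piperidine ring carrying a pyrrolidine, or an open-chain dimethylamino group on the ring attached to the carbonyl carbon, would give a number near that of compound 3 or near that of compound 4.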